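Swapping a Methoxy for a Hydroxyl on the Amide Aryl

The source may report more compounds than this note shows. Statements on the series, on what has been measured and on what is new or still open speak of the compounds shown alone.

Compound 1 `O=C(Nc1cc(C(F)(F)F)cc(C(F)(F)F)c1)C1NCCc2ccccc21` — in a functional assay on NUGC-3 cells (Homo sapiens) for inhibition, read by sulforhodamine B assay, with a stated time of 48 h (on this read-out higher numbers stand for weaker inhibition of growth and lower numbers for stronger inhibition of growth), compound 1 gives > 10000 nM, which is a limit of the assay rather than a number.
Compound 2 `O=C(Nc1ccc(C(F)(F)F)cc1)C1c2ccccc2CCN1C(=O)c1ccc(Cl)cc1` — compound 2 gives 4200 nM.
Compound 3 `COc1ccc(NC(=O)C2c3ccccc3CCN2C(=O)c2ccc(Cl)cc2)cc1` — compound 3 gives 3630 nM.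

Compound 3 stands lowest of the two numbers shown, with compound 2 nearest; the step of a 1.2-fold lower number from compound 2 to compound 3 (0.06 log units; within the scatter) lies within the scatter, so the two cannot be ordered. Compound 4 `O=C(Nc1cccc(O)c1)C1c2ccccc2CCN1C(=O)c1ccc(Cl)cc1` differs from compound 3 by 3-hydroxyphenyl in place of 4-methoxyphenyl on an amide-type nitrogen. Going by the values given here, no measured step touches this change; the only measured step, a 1.2-fold lower number from compound 2 to compound 3 (0.06 log units; within the scatter), exchanged one group on that same ring and moved the number within the scatter. So in this assay no step beyond the scatter is expected, and compound 4 is estimated at 4000 nM, ranging from 1500 nM to 12000 nM, a step of a 1.1-fold higher number from compound 3 to compound 4 (0.04 log units; within the scatter) that is expected to remain within the scatter.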

Compound 4, concentration for 50% growth inhibition: > 10000 nM
Compound 4: a limit, no number; the forecaster's own chance of this, stated with the estimate: 25%; middle value at least 2.5-fold (0.39 log units) away from the limit.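

The amide aryl ring is less forgiving than the earlier exchange suggested: 3-hydroxyphenyl gives an at least 2.7-fold higher number from compound 3 to compound 4 (0.44 log units; beyond the scatter) and an at least 2.3-fold higher number from compound 2 to compound 4 (0.37 log units; beyond the scatter), so growth inhibition weakens beyond the scatter. Compound 4 gives a limit of the assay and not a number, so these steps show only a smallest possible size: the limit of > 10000 nM in this assay, at which 2 of the 4 values shown sit.

The hydroxyl and its place on the ring changed together, and the compounds shown cannot separate the two. As far as these compounds go, how an amine or a carboxylic acid on that ring would behave remains open.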